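A few compounds are considered here, and "the series" means these few. Any claim that something is new, unique, unknown or untested is made for them only; others in the source may bear on it.

Compound 3, with structure `NC(=O)c1cnc2ccc(-c3cccnc3)cc2c1NCC1CCCCC1`, stands at the top of this small set in an ADME assay on cells (Hepatocyte, Homo sapiens) for metabolic stability, with a stated time of 90 min; a higher number here means faster removal of the compound, a lower number slower removal: compound 3 gives 40 uL/min. Its step from compound 2, `NC(=O)c1cnc2ccc(-c3cccnc3)cc2c1SC1CCCC1`, is a 2.2-fold higher number from compound 2 to compound 3 (0.35 log units; beyond the scatter), and this is the one gap that lies beyond the scatter; compound 2 gives 18 uL/min. Its step from compound 1, `NC(=O)c1cnc2ccc(-c3cccnc3)cc2c1NC1CCCC1`, is a 1.7-fold higher number from compound 1 to compound 3 (0.24 log units; within the scatter), which stays within the scatter, and compound 1 gives 23 uL/min. The remaining step, a 1.3-fold lower number from compound 1 to compound 2 (0.11 log units; within the scatter), is also within the scatter.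

Compound 4 has structure `CCC(CC)COc1c(C(N)=O)cnc2ccc(-c3cccnc3)cc12` and has not yet been measured in this assay. The change from compound 3 is 2-ethylbutoxy in place of (cyclohexylmethyl)amino on an aromatic carbon. Two of the measured steps bear on it: the exchange of the atom that links the side group to the core, a 1.3-fold lower number from compound 1 to compound 2 (0.11 log units; within the scatter), and the exchange of the carbon part of that side group, a 1.7-fold higher number from compound 1 to compound 3 (0.24 log units; within the scatter). Both moved the number by less than the scatter, and only their combination, a 2.2-fold higher number from compound 2 to compound 3 (0.35 log units; beyond the scatter), edged beyond it. Compound 4 combines both kinds of change at once, yet with a branched chain rather than a ring. He therefore expects a step of a 1.3-fold lower number from compound 3 to compound 4 (0.12 log units; within the scatter), that is, little or no movement beyond the scatter. His estimate for compound 4 in this assay is 30 uL/min, with a range from 15 uL/min to 60 uL/min.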

Compound 4, intrinsic clearance in a liver preparation (reported as CLH), per the amount of preparation that the assay uses: 42 uL/min
Estimate against measurement, compound 4: 1.4-fold (0.15 log units) below, within the range that was stated.
By their numbers in this assay, from the lowest: compounds 2, 1, 3 and 4 (each within the scatter of the next, the first and the last beyond it).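

Within the data shown here, at this aromatic carbon, opposite the ring nitrogen, compound 4 brings the first side group with no ring and no hydrogen-bond donor, and in this assay the exchange of (cyclohexylmethyl)amino for 2-ethylbutoxy gives a 1.1-fold higher number from compound 3 to compound 4 (0.02 log units; within the scatter). Neither the ring nor the donor of compound 3 is therefore required for a number at this level. Against cyclopentylamino the same 2-ethylbutoxy gives a 1.8-fold higher number from compound 1 to compound 4 (0.26 log units; within the scatter) and against cyclopentylsulfanyl it gives a 2.3-fold higher number from compound 2 to compound 4 (0.37 log units; beyond the scatter) so that compound 2 is separated beyond the scatter from both compound 3 and compound 4, while compound 1 lies within the scatter of all three others. Nothing available explains these numbers.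

The compounds shown leave open how a cyclopentyloxy or a (cyclohexylmethyl)sulfanyl group would stand in this assay and such groups would separate the linking atom from the carbon part of the side group. They also leave open whether an amine, a carboxylic acid or a longer chain at this position would move the number beyond the scatter of compound 3.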